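Compound 3 and its lengthened side chain

This account rests on a few compounds, and the source may have more. Where it says the series, first, only, none or still open, it means among the compounds named here.

In a physicochemical assay for solubility, in phosphate buffer (a lower number here means a less soluble compound, a higher number a more soluble compound), compound 1 (`COc1ccc(C2=[N+]3C(=Nc4c(-c5ccccc5)c5c(n4[B-]3(F)F)-c3ccc(OCC(=O)O)cc3CC5)C(c3ccccc3)=C2I)cc1`) gives 28400 nM, and compound 2 (`COc1ccc(C2=[N+]3C(=Nc4c(-c5ccccc5)c5c(n4[B-]3(F)F)-c3ccc(OCC(=O)N[C@@H](CC(=O)O)C(=O)O)cc3CC5)C(c3ccccc3)=C2I)cc1`) stands highest of the two at 165000 nM. Among the measured compounds shown here, the only measured step, a 5.8-fold higher number from compound 1 to compound 2 (0.76 log units; beyond the scatter), placed (1,2-dicarboxyethyl)amino in place of hydroxy on a carbonyl carbon. Compound 3 (`COc1ccc(C2=[N+]3C(=Nc4c(-c5ccccc5)c5c(n4[B-]3(F)F)-c3ccc(OCC(=O)N[C@@H](CCC(=O)O)C(=O)O)cc3CC5)C(c3ccccc3)=C2I)cc1`) differs from compound 2 by carboxymethyl in place of carboxy on a saturated chain carbon, two bonds along the chain from an amide-type nitrogen and a carbonyl carbon, with carboxymethyl in place of carboxy on a saturated chain carbon. That measured step concerns a different and larger change, so it offers only weak guidance, and no shift beyond the scatter is expected in this assay. The expected step is a 1.2-fold lower number from compound 2 to compound 3 (0.07 log units; within the scatter). For compound 3 the estimate is 140000 nM, within a range of 65000 nM to 290000 nM.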

Compound 3, solubility: 158000 nM
Compound 3: the middle estimate sits 1.1-fold (0.05 log units) below what was measured; the range from low to high includes it.
By their numbers in this assay, from the lowest: compound 1; then compounds 3 and 2 (each within the scatter of the next).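

In this assay, among the compounds shown here, carboxymethyl in place of carboxy on this saturated chain carbon gives a 1.0-fold lower number from compound 2 to compound 3 (0.02 log units; within the scatter) and so leaves the read-out within the scatter, which the earlier compounds could not show. For the compounds shown here, compound 3 also keeps the rise over compound 1, with a 5.6-fold higher number from compound 1 to compound 3 (0.75 log units; beyond the scatter) beyond the scatter, so this side chain tolerates the added carbon in the one change tested. No evidence on hand accounts for this result. As far as these compounds go, whether a longer chain at this carbon would hold the number stays open, as does the effect of an amine in place of the terminal carboxylic acid.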